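The compounds below may be only part of what the source reports. "The series", "measured", "known", "first", "only" and "open" are said of these compounds alone.

- Compound 1 `Nc1ncn(C[C@H]2CO[C@H](CO)O2)c(=O)n1` gives 70000 nM in a functional assay on B16-F10 cells (Mus musculus); a higher number here means that more compound is needed for the effect, a lower number that less compound is needed
- Compound 2 `Nc1ncn(C[C@H]2CO[C@@H](CO)O2)c(=O)n1` gives 60000 nM in this assay

Compound 2 stands level with compound 1 on these numbers: a 1.2-fold lower number from compound 1 to compound 2 (0.07 log units; within the scatter) lies within the scatter, so neither can be ranked above the other. The next compound, compound 3 `Nc1ncn(C[C@@H]2CO[C@@H](CO)O2)c(=O)n1`, is a close relative of compound 2. The change is the two compounds have the same atoms and bonds and differ only in configuration as drawn: 1 of 2 stereo elements differ; a stereocentre at a saturated ring carbon is drawn S in compound 2 and R in compound 3 and no group is added or removed. Going by the values given here, only one measured step bears on this kind of change, a 1.2-fold lower number from compound 1 to compound 2 (0.07 log units; within the scatter) just mentioned, which also altered a single stereocentre at a saturated ring carbon. The evidence is indirect, however. The stereocentre that changes now is not the one that changed in that step. Two compounds are also very little to go on, and a larger shift cannot be ruled out. Even so, the estimate means a 1.1-fold higher number from compound 2 to compound 3 (0.03 log units; within the scatter) in this assay and no step beyond the scatter is expected. Compound 3 is estimated at 65000 nM with 25000 nM to 150000 nM as the expected range.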

Compound 3, half-maximal effective concentration: 80000 nM
Compound 3: middle estimate off by 1.2-fold (0.09 log units), on the low side; the range from low to high includes it.
By their numbers in this assay, from the lowest: compounds 2, 1 and 3 (each within the scatter of the next).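

The second stereocentre now has its own measured step in this assay, and it behaves like the first: a 1.3-fold higher number from compound 2 to compound 3 (0.12 log units; within the scatter). Inverting both stereocentres at once, which turns one compound into its mirror image, gives no separation either, with a 1.1-fold higher number from compound 1 to compound 3 (0.06 log units; within the scatter). Among these three compounds, then, the drawn configuration at these saturated ring carbons, whether changed singly or together, produces no step beyond the scatter, and this comparison isolates configuration alone: the fact that compounds 1 and 3 differ only in the configuration as drawn

The compounds shown leave open whether the remaining combination of the two stereocentres would also stay level with these three. They also cannot show how the number would respond to a change in the atoms themselves, such as an amine or a carboxylic acid in place of the hydroxyl group on the shared core, since every comparison here keeps the same atoms and bonds.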